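Replacing the Ring on the Chain Carbon of Compound 2

The source may hold more compounds than are shown below. What is called first, only, known or untested is meant among the compounds shown, and "the series" means these compounds.

Of the compounds shown here, two have numbers so far in a functional assay on CHO cells for antagonist activity at prostaglandin E2 receptor EP3 subtype (Homo sapiens), read by cAMP accumulation; on this read-out lower numbers stand for stronger inhibition and higher numbers for weaker inhibition. Compound 1, `CCn1ncc2c(F)cc(-c3ccc(C(CC)(CC)c4nnc[nH]4)c(=O)[nH]3)cc21`, gives 29 nM in this assay. Compound 2, `CC(C)C(c1ccc(-c2ccc3cccc(F)c3c2)[nH]c1=O)N1CCN/C1=N\C#N`, gives 38 nM in this assay, which is the higher of the two numbers, though its gap to compound 1 lies within the scatter, so the two cannot be ranked against each other.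

Compound 3, `CC(C)C(c1noc(=O)[nH]1)c1ccc(-c2ccc3cccc(F)c3c2)[nH]c1=O`, has not yet been measured in this assay. It differs from compound 2 in one place: a group of 6 heavy atoms (2 carbon, 2 nitrogen, 2 oxygen; one five-membered aromatic ring with 3 hetero atoms) in place of a group of 8 heavy atoms (4 carbon, 4 nitrogen; one five-membered non-aromatic ring with 2 hetero atoms), on a saturated chain carbon bound to an aromatic carbon and a saturated chain carbon. Both groups carry one hydrogen-bond donor, and compound 1 also holds a five-membered aromatic heterocycle on the chain carbon bound to the aromatic carbon of its core, with a number close to that of compound 2.

For the measured compounds named here, no step between two measured compounds describes this change, so the expectation rests on the closeness of compound 1 and compound 2. Compound 3 is expected to stay near compound 2, with a step of a 1.1-fold higher number from compound 2 to compound 3 (0.02 log units; within the scatter) that is not expected to exceed the scatter. The estimate for compound 3 in this assay is 40 nM, within a range from 12 nM to 130 nM.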

Compound 3, half-maximal inhibitory concentration: 41 nM
Beside the measured number, compound 3's estimate is 1.0-fold (0.01 log units) below it, within the range that was stated.
By their numbers in this assay, from the lowest: compounds 1, 2 and 3 (each within the scatter of the next).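

On the saturated chain carbon bound to an aromatic carbon and a saturated chain carbon, a five-membered aromatic ring with 3 hetero atoms took the place of a five-membered non-aromatic ring with 2 hetero atoms, and this assay gave a 1.1-fold higher number from compound 2 to compound 3 (0.03 log units; within the scatter), so the two groups cannot be told apart on this read-out. For the compounds shown here, this is the first one-place comparison at this position, and it shows that on the shared core a number in this range does not depend on the group of 8 heavy atoms with its triple bond outside aromatic rings: the group of 6 heavy atoms, with 1 hydrogen-bond donor like the group it replaces and 3 hydrogen-bond acceptors rather than 2, reads the same within the scatter. No measurement is available that would explain this result.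

Both groups are five-membered rings carrying one hydrogen-bond donor, so the compounds shown leave open whether either feature matters at this carbon. A carboxylic acid, an amine or a plain methyl group there would test this, and a six-membered ring would test the ring size.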